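Swapping chloro for methoxy on an anticonvulsant series

The compounds below may be only part of what the source reports. "The series", "measured", "known", "first", "only" and "open" are said of these compounds alone.

- Compound 1 `COc1ccc(C2CC(Nc3nc4ccc(C)cc4s3)=NN2C(C)=O)cc1`: 37.3 umol/kg
- Compound 2 `CC(=O)N1N=C(Nc2nc3ccccc3s2)CC1c1ccccc1`: 315 umol/kg
- Compound 3 `CC(=O)N1N=C(Nc2nc3ccccc3s2)CC1c1ccc(Cl)cc1`: 209 umol/kg
- Compound 4 `COc1ccc(C2CC(Nc3nc4ccccc4s3)=NN2C(C)=O)cc1`: not yet measured

All three values come from a functional assay on the whole organism (Hindlimb, strain albino) with Mus musculus as the target, in the maximal electroshock model, with a stated time of 0.5 h; on this read-out higher numbers stand for an effect only at larger amounts of compound and lower numbers for an effect already at smaller amounts. Compound 3 lies within the usual scatter of compound 2, while compound 1 has a lower number, by more than the scatter.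

The next step replaces one group on compound 3: methoxy in place of chloro on an aromatic carbon. In words, methoxy takes the place of chloro on an aromatic carbon.

Among the measured compounds shown here, only one measured step changes this same spot, a 1.5-fold lower number from compound 2 to compound 3 (0.18 log units; within the scatter). That step puts chloro in place of hydrogen, and it does not exceed the scatter, so the spot has shown little so far. For the measured compounds named here, no measured step isolates the methoxy group. Still, compound 1 also carries methoxy and gives 37.3 umol/kg, which hints at a lower number, though its core is not identical.

A modest move downward in this assay is therefore expected, and the estimated change is a 2.1-fold lower number from compound 3 to compound 4 (0.32 log units; beyond the scatter). The estimate for compound 4 is 100 umol/kg, with an expected range from 35 umol/kg to 280 umol/kg.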

Compound 4, dose for half-maximal effect: 226 umol/kg
Compound 4: middle estimate off by 2.3-fold (0.35 log units), on the low side, within the range that was stated.
By their numbers in this assay, from the lowest: compound 1; then compounds 3, 4 and 2 (each within the scatter of the next).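

In this assay, the 4-chlorophenyl to 4-methoxyphenyl change makes no real difference at this spot (a 1.1-fold higher number from compound 3 to compound 4 (0.03 log units; within the scatter)), and methoxy does not stand out from hydrogen there either (a 1.4-fold lower number from compound 2 to compound 4 (0.14 log units; within the scatter)). Methoxy alone therefore does not reproduce the low number of compound 1 (37.3 umol/kg); the one new step beyond the scatter lies elsewhere on the molecule, at the methyl group on the core (a 6.1-fold higher number from compound 1 to compound 4 (0.78 log units; beyond the scatter)). No measurement shown here explains why the groups at this spot read alike or why the methyl group matters.

From the compounds shown here alone, it remains open whether that methyl group would give a similar step with chloro or hydrogen in place of methoxy. Going by these compounds, it is also open whether an amine or a carboxylic acid at the spot para to a large group would shift the number beyond the scatter.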